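Working notes: from compound 2 to compound 3

The compounds below may be only part of what the source reports. "The series", "measured", "known", "first", "only" and "open" are said of these compounds alone.

Two members of the series have been read in an ADME assay on HepG2 cells (Homo sapiens) for cytotoxicity, read by MTT assay, with a stated time of 72 h; on this read-out higher numbers stand for lower toxicity in this test and lower numbers for higher toxicity in this test. Compound 1 `COc1ccc(-c2cc(Cl)cn3c([N+](=O)[O-])c(CS(=O)(=O)c4ccccc4)nc23)cc1` gives > 3900 nM, which is a limit of the assay rather than a number. Compound 2 `N#Cc1ccc(-c2cc(Cl)cn3c([N+](=O)[O-])c(CS(=O)(=O)c4ccccc4)nc23)cc1` gives > 3900 nM, likewise a limit of the assay and not a number. For the measured compounds named here, the step that the two limits leave unreadable from compound 1 to compound 2 therefore cannot be read, and the only evidence on the numbers is the limit of > 3900 nM in this assay, at which 2 of the 2 values shown sit. Compound 2 thus stands at the limit, with no measured value on either side of it.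

Compound 3 `O=[N+]([O-])c1c(CS(=O)(=O)c2ccccc2)nc2c(-c3ccccc3C(F)(F)F)cc(Cl)cn12` differs from compound 2 in one place: 2-(trifluoromethyl)phenyl in place of 4-cyanophenyl on an aromatic carbon. The group leaving is 4-cyanophenyl; the group entering is 2-(trifluoromethyl)phenyl. Going by the values given here, no measured step bears directly on this change. Among the compounds with values here, the one measured step, a step that the two limits leave unreadable from compound 1 to compound 2, concerns a different pair of groups and is itself unreadable. Both measured compounds sit at the limit, so for compound 3 in this assay a limit is again expected, and the step that the limit leaves unreadable from compound 2 to compound 3 is expected to be no larger than the scatter. Compound 3 is estimated at 5000 nM, within 2000 nM to 20000 nM.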

Compound 3, half-maximal cytotoxic concentration: 22700 nM
Estimate against measurement, compound 3: 4.5-fold (0.66 log units) below; measured number outside the range, above it.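

No step from compound 1 or compound 2 to compound 3 can be read in this assay, because compound 1 and compound 2 stand only at a limit of the assay: the limit of > 3900 nM in this assay, at which 2 of the 3 values shown sit.

The compounds shown leave open how compound 3, at 22700 nM, compares with any numerical value for compound 1 or compound 2, and whether either group change moves this read-out.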